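Sulfonamide nitrogen: isopropyl replaced by 4-methoxyphenyl

This account rests on a few compounds, and the source may have more. Where it says the series, first, only, none or still open, it means among the compounds named here.

Going by the values given here, compound 2 `CC(C)NS(=O)(=O)c1ccc2c(c1)C(n1ccccc1=O)=CC(C)(C)O2` gives 676 nM in a functional assay with Rattus norvegicus as the target (a higher number here means that more compound is needed for the effect, a lower number that less compound is needed), the highest of the two single numbers so far; the nearest is compound 1 `CCNS(=O)(=O)c1ccc2c(c1)C(n1ccccc1=O)=CC(C)(C)O2`, which gives 56.2 nM, so that the small growth from ethyl to isopropyl on the sulfonamide nitrogen reads a 12-fold higher number from compound 1 to compound 2 (1.08 log units; beyond the scatter). Compound 3 `CC1(C)C=C(n2ccccc2=O)c2cc(S(=O)(=O)Nc3ccccc3)ccc2O1`, which carries a phenyl on the sulfonamide nitrogen, gives 3.09 nM; 2 nM (2 entries) in this assay, and its repeat entries agree with each other (the several entries of compound 3 in this assay, 3.09 nM; 2 nM (2 entries)).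

Compound 4 `COc1ccc(NS(=O)(=O)c2ccc3c(c2)C(n2ccccc2=O)=CC(C)(C)O3)cc1` differs from compound 2 by 4-methoxyphenyl in place of isopropyl on a sulfonamide nitrogen. Among the compounds with values here, no measured step covers this exact change; the only single-place step, that from compound 1 to compound 2, concerns alkyl branching and points upward. The aromatic substituent of compound 3, however, gives numbers far below both alkyl compounds. Compound 4 is therefore expected to fall close to compound 3, with the expected step of a 170-fold lower number from compound 2 to compound 4 (2.23 log units; beyond the scatter) being a large drop, well beyond the scatter. The estimate for compound 4 is 4 nM, within 1.5 nM to 15 nM.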

Compound 4, half-maximal effective concentration: 117 nM
For compound 4 the middle estimate is 29-fold (1.47 log units) below the measured one; the measured number lies above the stated range.
By their numbers in this assay, from the lowest: compound 1; then compound 4; then compound 2.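

In this assay, an aromatic group on the sulfonamide nitrogen does not by itself bring a compound into the range of compound 3: the change from isopropyl to 4-methoxyphenyl gives a 5.8-fold lower number from compound 2 to compound 4 (0.76 log units; beyond the scatter), while the change from ethyl gives a 2.1-fold higher number from compound 1 to compound 4 (0.32 log units; beyond the scatter). The larger group therefore recovers much of what branching lost, but it still sits modestly above the ethyl compound, and the printed values place compound 4 well above compound 3, which carries phenyl in place of 4-methoxyphenyl. That gap does not rest on a single reading of compound 3: the several entries of compound 3 in this assay, 3.09 nM; 2 nM (2 entries)

With only one substituted aromatic group shown on this nitrogen, it remains open whether 4-chlorophenyl or 4-methylphenyl would stay close to phenyl or to 4-methoxyphenyl. From the compounds shown here alone, the alkyl side is also open, with a longer chain such as n-butyl or a ring such as cyclohexyl still to be placed against ethyl and isopropyl.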